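This account rests on a few compounds, and the source may have more. Where it says the series, first, only, none or still open, it means among the compounds named here.

For the measured compounds named here, in a functional assay on HCT-15 cells (Homo sapiens) for cytotoxicity, read by ELISA, with a stated time of 2 days (on this read-out higher numbers stand for weaker inhibition and lower numbers for stronger inhibition), two compounds have numbers so far. Compound 1 `Oc1cccc(-c2cc(-c3ccccc3)cc(-c3cccs3)n2)c1` gives 10900 nM, and compound 2 `Oc1ccc(-c2cc(-c3ccccc3)cc(-c3ccccc3)n2)cc1` gives 3700 nM, the lower of the two numbers, with a gap beyond the usual scatter. Compound 3 `Oc1ccc(-c2cc(-c3ccccc3)cc(-c3cccs3)n2)cc1` is still unmeasured. It carries thiophen-2-yl in place of phenyl on an aromatic carbon of compound 2, next to the ring nitrogen: thiophen-2-yl in place of phenyl on an aromatic carbon. Going by the values given here, no measured pair isolates this change, so its size can only be judged loosely. Compound 1 also bears thiophen-2-yl and gives 10900 nM, which leans the expectation towards weaker inhibition in this assay. The expected step of a 1.4-fold higher number from compound 2 to compound 3 (0.13 log units; within the scatter) is small and within the scatter. For compound 3 the estimate is 5000 nM, with an expected range of 1900 nM to 13000 nM.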

Compound 3, half-maximal inhibitory concentration: 12500 nM
Compound 3: middle estimate off by 2.5-fold (0.40 log units), on the low side, within the range that was stated.
By their numbers in this assay, from the lowest: compound 2; then compounds 1 and 3 (each within the scatter of the next).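

In this assay, the change from phenyl to thiophen-2-yl on the aromatic carbon next to the ring nitrogen now has a direct measure: a 3.4-fold higher number from compound 2 to compound 3 (0.53 log units; beyond the scatter) and so phenyl gives the lower number of this pair, with 4-hydroxyphenyl held constant. With thiophen-2-yl in place, the swap of 3-hydroxyphenyl for 4-hydroxyphenyl gives a 1.1-fold higher number from compound 1 to compound 3 (0.06 log units; within the scatter) and so does not separate the two hydroxyphenyl groups. No measurement at hand accounts for the thiophen-2-yl step.

The compounds shown leave open whether the hydroxyphenyl swap would also stay within the scatter with phenyl at this position. They also leave open how a non-aromatic group at this carbon, such as an amine or a carboxylic acid, would compare with phenyl and thiophen-2-yl.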